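Indole azole series: ring swap and aryl substituent variation

This account rests on a few compounds, and the source may have more. Where it says the series, first, only, none or still open, it means among the compounds named here.

Measured compounds:
compound 1 `COc1ccc2c(Cn3ccnc3)c(-c3ccc(Cl)cc3)[nH]c2c1`, 1060 nM
compound 2 `Clc1ccc(-c2[nH]c3cc(Cl)ccc3c2Cn2cncn2)cc1`, 208 nM

In an assay on isolated protein for inhibition of Aromatase (Homo sapiens), read by ELISA, using NADPH, with a stated time of 24 h (on this read-out lower numbers stand for stronger inhibition and higher numbers for weaker inhibition), compound 2 gives 208 nM, the lowest of the two numbers; compound 1 gives 1060 nM, a higher number beyond the scatter. Going by the values given here, compound 1 and compound 2 differ in two places, so no single step is known. Compound 3 `COc1ccc2c(Cn3cncn3)c(-c3ccc(Cl)cc3)[nH]c2c1` is not yet measured. It carries methoxy in place of chloro on an aromatic carbon. Among the compounds with values here, since the only compound bearing methoxy, compound 1 with 1060 nM, also differs in the azole, the expected step of a 1.9-fold higher number from compound 2 to compound 3 (0.28 log units; within the scatter) is a modest weakening, possibly within the scatter. Compound 3 is estimated at 400 nM, range 150 nM to 1200 nM.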

Compound 3, half-maximal inhibitory concentration: 7770 nM
For compound 3 the middle estimate is 19-fold (1.29 log units) below the measured one; the whole stated range lies below it.
By their numbers in this assay, from the lowest: compound 2; then compound 1; then compound 3.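

In this assay, methoxy in place of chloro on this aromatic carbon gives a 37-fold higher number from compound 2 to compound 3 (1.57 log units; beyond the scatter) and shows that, with the triazole held constant, this position is highly sensitive to the change. With methoxy held constant, 1H-1,2,4-triazol-1-yl in place of 1H-imidazol-1-yl gives a 7.3-fold higher number from compound 1 to compound 3 (0.87 log units; beyond the scatter), so the azole also matters and the two changes act in opposite directions. Nothing available explains either step.

As far as these compounds go, the size of the chloro to methoxy step with the imidazole in place remains open. So does where fluoro, methyl or a nitrile on this carbon would fall.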